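This account rests on a few compounds, and the source may have more. Where it says the series, first, only, none or still open, it means among the compounds named here.

Compound 1 `COc1ccc(C2OC(c3ccc4ccccc4c3)=NN2C(C)=O)cc1` gives 6.86 ug/mL in the series
Compound 2 `CC(=O)N1N=C(c2ccc3ccccc3c2)OC1c1cccc(Br)c1` gives 2.36 ug/mL in the series
Compound 3 `CC(=O)N1N=C(c2ccc3ccccc3c2)OC1c1ccccc1Cl` gives 4.93 ug/mL in the series

All three numbers come from a functional assay on B16-F10 cells (Mus musculus) for antiproliferative activity, read by MTT assay, with a stated time of 48 h (a higher number here means a weaker inhibitor, a lower number a stronger inhibitor), and differ only in the substituted phenyl group on a saturated ring carbon. The number for compound 3 is not separated from that of compound 1 but stands clear of the number for compound 2. The steps read a 1.4-fold lower number from compound 1 to compound 3 (0.14 log units; within the scatter) and a 2.1-fold higher number from compound 2 to compound 3 (0.32 log units; beyond the scatter) in this set.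

Compound 4 `CC(=O)N1N=C(c2ccc3ccccc3c2)OC1c1ccccc1F` carries one change from compound 3: fluoro in place of chloro on an aromatic carbon on the ring carbon ortho to a large group. Among the compounds with values here, no measured step swaps chloro for fluoro. The nearest evidence is the exchange of the whole substituted phenyl group, and these steps reach only a modest size, the largest being a 2.9-fold lower number from compound 1 to compound 2 (0.46 log units; beyond the scatter) in this set. The smaller swap of chloro for fluoro is therefore expected to stay within the scatter in this assay with no direction favoured. The expected change is a 1.0-fold lower number from compound 3 to compound 4 (0.01 log units; within the scatter) by this estimate. Compound 4 is expected at 4.8 ug/mL within an estimated range of 2.2 ug/mL to 10 ug/mL overall.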

Compound 4, half-maximal inhibitory concentration: 6.05 ug/mL
Compound 4: middle estimate off by 1.3-fold (0.10 log units), on the low side, within the range that was stated.
By their numbers in this assay, from the lowest: compound 2; then compounds 3, 4 and 1 (each within the scatter of the next).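

In this assay, within the data shown here, the exchange of chloro for fluoro on an aromatic carbon ortho to a large group gives the first direct halogen comparison at this place, and it does not separate the pair (a 1.2-fold higher number from compound 3 to compound 4 (0.09 log units; within the scatter)). Among these compounds, the 2-fluorophenyl group also stays level with the 4-methoxyphenyl group (a 1.1-fold lower number from compound 1 to compound 4 (0.05 log units; within the scatter)), whereas the 3-bromophenyl group stands apart (a 2.6-fold higher number from compound 2 to compound 4 (0.41 log units; beyond the scatter)), leaving compound 2 as the only compound clear of all the others. No measurement available here gives a reason for this separation.

On these data alone, compound 2 differs from compound 3 and compound 4 in both the halogen and its place on the phenyl group, so the contribution of each stays open. Also open, as far as these compounds go, is how a phenyl group carrying an amine or a carboxylic acid would read.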